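Rearranging the cyanoguanidine tail on the longest chain

A few compounds are considered here, and "the series" means these few. Any claim that something is new, unique, unknown or untested is made for them only; others in the source may bear on it.

Of the compounds shown here, three have been measured in a functional assay on the whole organism with Rattus norvegicus as the target, at a dose of 100 mg/kg; a higher number here means more inhibition at the dose given (going by the name of the read-out), a lower number less inhibition. Compound 1 `CC/N=C(\S)NCCCCCCn1nc(-c2ccccc2)ccc1=O` gives -5.6%, compound 2 `CCC/N=C(/NC#N)NCCCCCn1nc(-c2ccccc2)ccc1=O` gives 27.5%, and compound 3 `CCC/N=C(/NC#N)NCCCn1nc(C)ccc1=O` gives 17.5%. Compound 2 stands highest of the three numbers; compound 3 sits a number lower but within the scatter, so the two cannot be ordered, while compound 1 lies far lower, beyond the scatter.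

Among the compounds with values here, the only single-place step in this set is the one that replaced the thiourea-type group in compound 1, and it gave a number 33.1 percentage points higher from compound 1 to compound 2 (beyond the scatter). That step shows that the group attached at that chain carbon matters to the read-out in this assay.

The unmeasured compound 4 `CN(C)/C(=N/CCCCCCn1nc(-c2ccccc2)ccc1=O)NC#N` keeps the same atoms as compound 2 but joins them differently: a group of 9 heavy atoms (5 carbon, 4 nitrogen; no ring) in place of a group of 9 heavy atoms (5 carbon, 4 nitrogen; no ring), on a saturated chain carbon, five bonds along the chain from an aromatic nitrogen. One hydrogen-bond donor is lost while the acceptor count stays. Within the data shown here, no measured step speaks to such a rearrangement, so no step beyond the scatter is predicted; a small drop is the more cautious guess. The expected change from compound 2 is a number 7.5 percentage points lower from compound 2 to compound 4 (within the scatter), and compound 4 is therefore estimated at 20%, within a range from 0% to 40%.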

Compound 4, a percentage reported as inhibition, in the whole organism at one dose (the size of the read-out at that dose, not a potency): 58.4%
Beside the measured number, compound 4's estimate is 38.4 percentage points below it; the measured number lies above the stated range.
By their numbers in this assay, from the lowest: compound 1; then compounds 3 and 2 (each within the scatter of the next); then compound 4.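

In this assay, within the data shown here, the earlier compounds showed only that exchanging one group for a different one at this saturated chain carbon can shift the number; the new result shows that rearranging the same atoms can shift it too, with a number 30.9 percentage points higher from compound 2 to compound 4 (beyond the scatter). The two groups have the same 9 heavy atoms (5 carbon, 4 nitrogen), the same 2 hydrogen-bond acceptors and the same double and triple bond, but the group that leaves has 2 hydrogen-bond donors and the group that enters has 1, so the atom count alone does not settle the read-out here. The sulfur-containing group of compound 1 also compares poorly with the new group, with a number 64 percentage points higher from compound 1 to compound 4 (beyond the scatter).

Nothing available explains why the rearranged group gives the higher number, and the lost hydrogen-bond donor cannot be separated from the other changes in how the atoms are joined. On these data alone, it also remains open whether the number would hold with an ethyl group or a morpholine ring in the tail of compound 4, or with a methyl group in place of the phenyl group on the core.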